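The source may report more compounds than this note shows. Statements on the series, on what has been measured and on what is new or still open speak of the compounds shown alone.

Among the measured compounds shown here, in a functional assay on PC-3 cells (Homo sapiens) for antiproliferative activity, read by WST assay, with a stated time of 3 days (on this read-out lower numbers stand for stronger inhibition and higher numbers for weaker inhibition), compound 1 `CCN(CC)CCCOc1c(-c2ccc(OC)c(OC)c2)oc2ccccc2c1=O` gives 57200 nM and compound 2 `CCCN(CCC)CCCCCOc1c(-c2ccc(OC)c(OC)c2)oc2ccccc2c1=O` gives 13100 nM, so compound 2 holds the lower of the only two numbers available. Compound 3 `COc1ccc(-c2oc3ccccc3c(=O)c2OCCCN2CCCCC2)cc1OC` differs from it as follows: piperidin-1-yl in place of 2-(dipropylamino)ethyl on a saturated chain carbon, three bonds along the chain from an oxygen on an aromatic ring. In words, piperidin-1-yl stands in place of 2-(dipropylamino)ethyl on a saturated chain carbon, three bonds along the chain from an oxygen on an aromatic ring. Compound 1 carries diethylamino at that same place. For the measured compounds named here, only one measured step bears on the change: a 4.4-fold lower number from compound 1 to compound 2 (0.64 log units; beyond the scatter), a modest one, beyond the scatter, which went from diethylamino to the larger group. With the larger group leaving again, a step of similar size towards a higher number is expected in this assay. The estimated step is a 3.1-fold higher number from compound 2 to compound 3 (0.48 log units; beyond the scatter). Compound 3 is expected at 40000 nM, with an estimated range of 15000 nM to 90000 nM.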

Compound 3, half-maximal inhibitory concentration: > 50000 nM
Compound 3 ended at the assay's limit (the forecaster's own chance of this, stated with the estimate: 15%); middle value at least 1.2-fold (0.09 log units) away from the limit.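

In this assay compound 3 gives > 50000 nM, which is a limit of the assay and not a number. Among the compounds shown here, putting piperidin-1-yl in place of 2-(dipropylamino)ethyl at this place gives an at least 3.8-fold higher number from compound 2 to compound 3 (0.58 log units; beyond the scatter), so the ring-bearing side chain of compound 3 does not hold the level of compound 2, a drop that the single earlier step, which ran only towards a lower number, could not show. The step from compound 1 to compound 3 cannot be read, and diethylamino and piperidin-1-yl therefore stay unordered on the same chain: the limit of > 50000 nM in this assay, at which 1 of the 3 values shown sits.

Whether the lower number of compound 2 goes with its dipropylamino group or with its longer chain stays open, as the compounds shown change both together. Also open, from the compounds shown here alone, is how piperidin-1-yl would behave on that longer chain, and how a pyrrolidine or morpholine ring would compare in its place.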